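The compounds below may be only part of what the source reports. "The series", "measured", "known", "first", "only" and "open" are said of these compounds alone.

Compound 1 `COc1ccc(Cc2nnc(NC(=O)/C(C#N)=C/c3ccccc3OS(=O)(=O)c3ccc(OC)cc3)s2)cc1`: 78%
Compound 2 `COc1ccc(Cc2nnc(NC(=O)/C(C#N)=C/c3ccccc3OS(=O)(=O)c3ccc(Cl)cc3)s2)cc1`: 79%

Both compounds were tested in a functional assay on RS4-11 cells (Homo sapiens) for inhibition, read by CCK-8 assay, with a stated time of 48 h, tested at 20 uM; a higher number here means more inhibition of growth at the concentration tested, a lower number less inhibition of growth. For the measured compounds named here, there, compound 2 gives 79%, and its only measured neighbour is compound 1, which lies within the usual scatter of it. The two are therefore best read as equal.

Compound 3 `COc1ccc(Cc2nnc(NC(=O)/C(C#N)=C/c3ccccc3OS(=O)(=O)c3ccc(F)cc3)s2)cc1` has not yet been measured. It keeps the whole structure of compound 2 except for one substituent, with fluoro in place of chloro on an aromatic carbon.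

Going by the values given here, only one measured step bears on this carbon. The exchange of methoxy for chloro there gave a number 1 percentage points higher from compound 1 to compound 2 (within the scatter). That is a single step and thin evidence, but it offers no reason to expect a change in this assay beyond the scatter, in either direction.

The expected outcome is a number 1 percentage points lower from compound 2 to compound 3 (within the scatter), which would be no real change. For compound 3 the estimated value is 78%, with an expected range of 67% to 88%.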

Compound 3, percent growth inhibition at one concentration: 80%
Estimate against measurement, compound 3: 2 percentage points below, and the stated range covers the measured number.
By their numbers in this assay, from the lowest: compounds 1, 2 and 3 (each within the scatter of the next).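

Swapping chloro for fluoro on this aromatic carbon gives a number 1 percentage points higher from compound 2 to compound 3 (within the scatter) in this assay, and the wider swap of methoxy for fluoro gives a number 2 percentage points higher from compound 1 to compound 3 (within the scatter) on the same read-out. For the compounds shown here, three different groups at this site, para to a large group, now read as equal, where the earlier pair offered only one comparison, so neither the two halogens nor a halogen and methoxy can be told apart here. Nothing available explains why these groups read alike.

From the compounds shown here alone, whether this flat picture holds for a quite different group on this carbon, such as an amine, a carboxylic acid or a longer chain like butoxy, stays open. So does whether these three compounds would still read as equal at concentrations other than the single one used.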